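Hydrogen in place of hydroxy: working notes on the series

This account rests on a few compounds, and the source may have more. Where it says the series, first, only, none or still open, it means among the compounds named here.

Measured so far in a functional assay on IGROV-1 cells (Homo sapiens) for inhibition; on this read-out lower numbers stand for stronger inhibition of growth and higher numbers for weaker inhibition of growth
- compound 1 `COc1cc(/C=C/c2ccc(S(N)(=O)=O)cc2)cc(OC)c1` gives 23100 nM
- compound 2 `NS(=O)(=O)c1ccc(/C=C/c2ccc(O)c(O)c2)cc1` gives 4490 nM
- compound 3 `COc1cccc(/C=C/c2ccc(S(N)(=O)=O)cc2)c1` gives 2500 nM

Compound 2 (4490 nM) and compound 3 (2500 nM) lie within the scatter of each other, so neither can be ranked over the other. Compound 1 (23100 nM) carries a higher number than compound 2, and that gap lies beyond the scatter.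

The next case is compound 4 `NS(=O)(=O)c1ccc(/C=C/c2ccc(O)cc2)cc1` which, set against compound 2, has hydrogen in place of hydroxy on an aromatic carbon. The change falls ortho to a hydroxy group and meta to a large group.

Going by the values given here, one measured step bears on it, with hydrogen in place of methoxy on an aromatic carbon: a 9.2-fold lower number from compound 1 to compound 3 (0.97 log units; beyond the scatter), a modest step. Among the compounds with values here, no step in which hydroxy leaves has been measured, and methoxy is a different group, so this is a weak guide. Its direction points to a lower number in this assay for compound 4, though a smaller step is expected. The expected shift is a 1.8-fold lower number from compound 2 to compound 4 (0.25 log units; within the scatter) and this estimated step would stay within the scatter. The estimate for compound 4 is 2500 nM with an expected range (700 nM to 9000 nM).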

Compound 4, concentration for 50% growth inhibition: 20300 nM
Estimate against measurement, compound 4: 8.1-fold (0.91 log units) below, and the stated range ends below it.
By their numbers in this assay, from the lowest: compounds 3 and 2 (each within the scatter of the next); then compounds 4 and 1 (each within the scatter of the next).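

In this assay, going by these compounds alone, the step of a 4.5-fold higher number from compound 2 to compound 4 (0.66 log units; beyond the scatter) is the first measured case of hydroxy leaving, and it shows that a hydroxy at this place, ortho to a hydroxy group and meta to a large group, goes with stronger inhibition of growth than hydrogen does. That direction is opposite to the step of a 9.2-fold lower number from compound 1 to compound 3 (0.97 log units; beyond the scatter) in which hydrogen takes the place of methoxy, so across these two pairs hydrogen entering on the aromatic ring has no single direction, and the two pairs differ both in the group that leaves and in its surroundings. No measurement at hand accounts for the size or the direction of this step.

The compounds shown leave open whether the gain belongs to hydroxy itself or would also appear with an amine or a fluorine atom at the same place. Within the data shown here, they also leave open whether the step would keep its direction and size if the remaining hydroxy were exchanged for a carboxylic acid, since only one pair speaks for this change.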